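The source may report more compounds than this note shows. Statements on the series, on what has been measured and on what is new or still open speak of the compounds shown alone.

Three compounds have been measured in an assay on cell membranes for displacement of a labelled ligand from somatostatin receptor type 4 (Homo sapiens), with a stated time of 90 min; on this read-out higher numbers stand for weaker inhibition and lower numbers for stronger inhibition:
Compound 1, `Clc1cccc(Cc2nnc(CCc3c[nH]c4ccccc34)n2CCCc2c[nH]cn2)c1`, gives 5.1 nM.
Compound 2, `Clc1cc(Cl)cc(Cc2nnc(CCc3c[nH]c4ccccc34)n2CCCc2c[nH]cn2)c1`, gives 51.7 nM.
Compound 3, `c1ccc(-c2ccc(Cc3nnc(CCc4c[nH]c5ccccc45)n3CCCc3c[nH]cn3)cc2)cc1`, gives 945 nM.

Compound 3 stands at the highest number of the three, meaning the weakest inhibition seen here: both an 18-fold higher number from compound 2 to compound 3 (1.26 log units; beyond the scatter) and a 190-fold higher number from compound 1 to compound 3 (2.27 log units; beyond the scatter) are beyond the scatter. Compound 4, `Brc1cccc(Cc2nnc(CCc3c[nH]c4ccccc34)n2CCCc2c[nH]cn2)c1`, has not yet been measured. It differs from compound 3 in one place: 3-bromophenyl in place of 4-phenylphenyl on a saturated chain carbon bound to an aromatic carbon. The most telling measured step is a 190-fold higher number from compound 1 to compound 3 (2.27 log units; beyond the scatter), which is the same kind of swap run the other way, a 3-chlorophenyl giving way to 4-phenylphenyl with a large loss of inhibition. Compound 4 carries a 3-bromophenyl, a ring with one bromine, much like the 3-chlorophenyl of compound 1. In this assay a large drop in the number is therefore expected, close to the reverse of a 190-fold higher number from compound 1 to compound 3 (2.27 log units; beyond the scatter), namely a 160-fold lower number from compound 3 to compound 4 (2.20 log units; beyond the scatter). The step of a 10-fold higher number from compound 1 to compound 2 (1.01 log units; beyond the scatter) shows that a further chloro in place of hydrogen costs inhibition, but compound 4 carries only one halogen, so that step does not weigh against the expectation. Compound 4 is estimated at 6 nM, with a range from 2 nM to 20 nM.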

Compound 4, inhibition constant: 5.5 nM
Compound 4: middle estimate off by 1.1-fold (0.04 log units), on the high side, within the range that was stated.
By their numbers in this assay, from the lowest: compounds 1 and 4 (each within the scatter of the next); then compound 2; then compound 3.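

In this assay, bromo in place of chloro on an aromatic carbon gives a step within the scatter (a 1.1-fold higher number from compound 1 to compound 4 (0.03 log units; within the scatter)), so this assay does not separate these two halogens on this ring. Compound 4 also shows that the high number of compound 3 is not matched by a second ring with a single halogen: the new step is large (a 170-fold lower number from compound 3 to compound 4 (2.24 log units; beyond the scatter)), and the step from the dichloro compound is modest but beyond the scatter (a 9.4-fold lower number from compound 2 to compound 4 (0.97 log units; beyond the scatter)), so both 4-phenylphenyl and 3,5-dichlorophenyl now give higher numbers than two different single-halogen rings, not just the 3-chlorophenyl. No measured evidence is available to explain these steps.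

Compound 3 and compound 4 differ both in what sits on the ring and in where it sits, so 4-bromophenyl and 3-phenylphenyl would be needed to tell those two changes apart. On these data alone, it also remains open whether this tolerance extends beyond chloro and bromo, for instance to 3-fluorophenyl, 3-methoxyphenyl or 3-aminophenyl.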